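The source may hold more compounds than are shown below. What is called first, only, known or untested is meant among the compounds shown, and "the series" means these compounds.

- Compound 1 `COc1cc(/C=C2\CN(S(=O)(=O)c3ccc(NC(C)=O)cc3)C/C(=C\c3ccccc3F)C2=O)cc(OC)c1OC`: 2680 nM
- Compound 2 `COc1cc(/C=C2\CN(S(=O)(=O)c3ccc(NC(C)=O)cc3)C/C(=C\c3cccc([N+](=O)[O-])c3)C2=O)cc(OC)c1OC`: 2550 nM

Both numbers come from a functional assay on QGY-7703 cells (Homo sapiens) for cytotoxicity, read by MTT assay, with a stated time of 24 h; on this read-out lower numbers stand for stronger inhibition and higher numbers for weaker inhibition. Among the compounds with values here, compound 2 stands level with compound 1, the only other measured compound, since the two values lie within the scatter of each other. Compound 3 `COc1cc(/C=C2\CN(S(=O)(=O)c3ccc(NC(C)=O)cc3)C/C(=C\c3ccc(C#N)cc3)C2=O)cc(OC)c1OC` keeps the shared core and changes one group, with 4-cyanophenyl in place of 3-nitrophenyl on a double-bonded chain carbon bound to a double-bonded ring carbon.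

Within the data shown here, only one measured step bears on this place: a 1.1-fold lower number from compound 1 to compound 2 (0.02 log units; within the scatter). Exchanging one substituted phenyl group for another there left the number within the scatter. This is thin evidence, but it gives no reason to expect a real shift in this assay, in either direction. The expected change is a 1.0-fold lower number from compound 2 to compound 3 (0.01 log units; within the scatter), so no step beyond the scatter is expected. The estimate for compound 3 is 2500 nM, expected to fall between 1200 nM and 5000 nM.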

Compound 3, half-maximal inhibitory concentration: 1890 nM
For compound 3 the middle estimate is 1.3-fold (0.12 log units) above the measured one, within the range that was stated.
By their numbers in this assay, from the lowest: compounds 3, 2 and 1 (each within the scatter of the next).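

Putting 4-cyanophenyl at this place gives a 1.3-fold lower number from compound 2 to compound 3 (0.13 log units; within the scatter) and a 1.4-fold lower number from compound 1 to compound 3 (0.15 log units; within the scatter) in this assay on the same cells. Within the data shown here, three substituted phenyl groups, 2-fluorophenyl, 3-nitrophenyl and 4-cyanophenyl, now stand side by side on the shared core, and no pair of them separates beyond the scatter, so this position tolerates these exchanges without a measurable shift, even when the nitro group gives way to a nitrile and the substituent's place on the phenyl ring differs. Nothing measured here offers an explanation for these numbers.

Still open, going by these compounds, is whether an amine or a carboxylic acid on the phenyl ring, or a longer chain in place of that ring, would move the number beyond the scatter. Three compounds also cannot show whether this flat picture holds for the other substituted phenyl group on the core.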